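A few compounds are considered here, and "the series" means these few. Any claim that something is new, unique, unknown or untested is made for them only; others in the source may bear on it.

Measured compounds:
compound 1, `O=C(Nc1cc(C(F)(F)F)cc(C(F)(F)F)c1)c1nsnc1O`, 4.34%
compound 2, `Cn1nc(O)c(C(=O)Nc2cc(C(F)(F)F)cc(C(F)(F)F)c2)n1`, 9.1%

In an assay on isolated protein for inhibition of mitogen-activated protein kinase kinase kinase 14 (Homo sapiens), read by ADP-Glo, with a stated time of 60 min, tested at 100 uM, in the presence of a further agent that is not named here (a lower number here means less inhibition, a higher number more inhibition at the concentration tested (going by the name of the read-out)), compound 1 stands lowest of the two numbers shown, with compound 2 nearest to it; the step of a number 4.8 percentage points higher from compound 1 to compound 2 (within the scatter) lies within the scatter. Compound 3, `Cc1c(C(=O)Nc2cc(C(F)(F)F)cc(C(F)(F)F)c2)c(O)nn1C`, has not yet been measured. It differs from compound 1 in this way: a group of 8 heavy atoms (5 carbon, 2 nitrogen, 1 oxygen; one five-membered aromatic ring with 2 hetero atoms) in place of a group of 6 heavy atoms (2 carbon, 2 nitrogen, 1 oxygen, 1 sulfur; one five-membered aromatic ring with 3 hetero atoms), on a carbonyl carbon. The only step shown, from compound 1 to compound 2, also exchanged the ring on the carbonyl carbon and stayed within the scatter. A similar outcome is therefore expected here, with a step of a number 2.7 percentage points higher from compound 1 to compound 3 (within the scatter) no larger than the scatter. Compound 3 is estimated to give 7%, within -5% to 20%.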

Compound 3, a percentage reported as inhibition, at one concentration (the size of the read-out at that concentration, not a potency): 24.1%
The estimate for compound 3 lay 17.1 percentage points below the measured number; the measured number lies above the stated range.
By their numbers in this assay, from the lowest: compounds 1 and 2 (each within the scatter of the next); then compound 3.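

In this assay, the group on the carbonyl carbon can move the number after all: placing 3-hydroxy-1,5-dimethyl-1H-pyrazol-4-yl there gives a number 19.8 percentage points higher from compound 1 to compound 3 (beyond the scatter), and a number 15 percentage points higher from compound 2 to compound 3 (beyond the scatter). The earlier exchange of one ring for another showed no such separation, and even here the change remains modest. Nothing measured here accounts for the rise.

Still open, on these data alone, is whether the gain belongs to the pyrazole ring itself or to its methyl groups. Also open, as far as these compounds go, is how an amine or a carboxylic acid in place of the hydroxyl group would read.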